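Ester to Amide on a Shared Core: Cytotoxicity Outlook

The source may hold more compounds than are shown below. What is called first, only, known or untested is meant among the compounds shown, and "the series" means these compounds.

Compound 1 `COc1ccc(-c2cc(-c3ccc4c(c3)CCCC4)nc(Cl)c2C#N)cc1OC` stops at a limit of the assay, > 50000 nM, in an ADME assay on RAW264.7 cells (Mus musculus) for cytotoxicity, with a stated time of 24 h; on this read-out higher numbers stand for weaker inhibition and lower numbers for stronger inhibition.
Compound 2 `CCOC(=O)COc1nc(-c2ccc3c(c2)CCCC3)cc(-c2ccc(OC)c(OC)c2)c1C#N` gives 26200 nM in this assay.
Compound 3 `CCOC(=O)COc1nc(-c2ccc3c(c2)CCCC3)cc(-c2ccc(C(C)C)cc2)c1C#N` stops at a limit of the assay, > 50000 nM, in this assay.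

Among the measured compounds shown here, compound 2 therefore holds the only actual number among the three; the other two sit at the limit of > 50000 nM in this assay, at which 2 of the 3 values shown sit. Compound 4 `COc1ccc(-c2cc(-c3ccc4c(c3)CCCC4)nc(OCC(=O)NCc3ccccc3)c2C#N)cc1OC` differs from compound 2 in a single place: benzylamino in place of ethoxy on a carbonyl carbon. The two measured steps touch other parts of the shared core. an at least 1.9-fold lower number from compound 1 to compound 2 (0.28 log units; that floor lies within the scatter). an at least 1.9-fold higher number from compound 2 to compound 3 (0.28 log units; that floor lies within the scatter). Both are floors that lie within the scatter, and neither alters the ester end, so they give no direct guide to swapping an ethoxy for a benzylamino on the carbonyl carbon. With nothing pointing either way, no step beyond the scatter is expected, and the expected step is a 1.1-fold higher number from compound 2 to compound 4 (0.06 log units; within the scatter). Compound 4 is accordingly estimated at 30000 nM in this assay, with a range from 12000 nM to 80000 nM, and a real chance that it, too, is reported only as a limit.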

Compound 4, half-maximal inhibitory concentration: 8400 nM
Estimate against measurement, compound 4: 3.6-fold (0.55 log units) above; the measured number lies below the stated range.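

Changing the end of the chain on this carbonyl carbon gives a step that lies clearly beyond the scatter, which neither earlier step did: in this assay, benzylamino in place of ethoxy gives a 3.1-fold lower number from compound 2 to compound 4 (0.49 log units; beyond the scatter). Against the chloro compound, (benzylcarbamoyl)methoxy in place of chloro gives an at least 5.9-fold lower number from compound 1 to compound 4 (0.77 log units; beyond the scatter). That step can be read only as a floor, because compound 1 stands at a limit of the assay: the limit of > 50000 nM in this assay, at which 2 of the 4 values shown sit.

The compounds shown do not separate the part played by the amide hydrogen from that of the benzyl ring, which a methylamino or dimethylamino group on the same carbonyl carbon could help to do. They also leave open whether benzylamino gives a similar step when 4-isopropylphenyl, as in compound 3, replaces 3,4-dimethoxyphenyl.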